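Thiophene isomer swap in the cyclopropylethyl series

A few compounds are considered here, and "the series" means these few. Any claim that something is new, unique, unknown or untested is made for them only; others in the source may bear on it.

Measured so far:
compound 1 `NC(=O)COc1ccc2c(c1)S(=O)(=O)N=C(c1c(O)c(-c3cccs3)nn(CCC3CC3)c1=O)N2`: 0.2 h
compound 2 `CC(C)(C)CCn1nc(-c2cccs2)c(O)c(C2=NS(=O)(=O)c3cc(OCC(N)=O)ccc3N2)c1=O`: 0.35 h
compound 3 `CC(C)(F)CCn1nc(-c2cccs2)c(O)c(C2=NS(=O)(=O)c3cc(OCC(N)=O)ccc3N2)c1=O`: 0.65 h

In an in vitro ADME assay on microsomes from liver (Homo sapiens) for metabolic stability (a lower number here means that the compound disappears faster, a higher number that the compound lasts longer), compound 1 gives 0.2 h, the lowest of the three numbers; the nearest step is a 1.8-fold higher number from compound 1 to compound 2 (0.24 log units; within the scatter), the furthest a 3.3-fold higher number from compound 1 to compound 3 (0.51 log units; beyond the scatter), the only one beyond the scatter. Between the other two, a 1.9-fold higher number from compound 2 to compound 3 (0.27 log units; within the scatter). Compound 4 `NC(=O)COc1ccc2c(c1)S(=O)(=O)N=C(c1c(O)c(-c3ccsc3)nn(CCC3CC3)c1=O)N2` differs from compound 1 by thiophen-3-yl in place of thiophen-2-yl on an aromatic carbon. Among the compounds with values here, none of the measured steps bears on this change: all three concern the 2-cyclopropylethyl group, not the thiophene, so no step with the same or a related change is available. With nothing to point in either direction, the expected step in this assay is none beyond the scatter, no change at the digits printed from compound 1 to compound 4 (within the scatter). Compound 4 is therefore estimated at 0.2 h, range 0.1 h to 0.45 h.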

Compound 4, half-life: 0.267 h
For compound 4 the middle estimate is 1.3-fold (0.13 log units) below the measured one; low and high end bracket the measured number.
By their numbers in this assay, from the lowest: compounds 1, 4, 2 and 3 (each within the scatter of the next, the first and the last beyond it).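

In this assay, within the data shown here, exchanging the ring at this carbon next to the ring nitrogen gives a 1.3-fold higher number from compound 1 to compound 4 (0.13 log units; within the scatter), the only reading here on the thiophene rather than the 2-cyclopropylethyl group. In this one pair, with the 2-cyclopropylethyl group held constant, the thiophene attachment point leaves the number within the scatter. Nothing at hand explains this step.

On these data alone, whether the swap reads the same on the chains of compound 2 and compound 3 stays open. So does whether a phenyl or pyridine ring at this carbon would move the number beyond the scatter.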